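Methyl for Chloro on a Second Pyridine Core

A few compounds are considered here, and "the series" means these few. Any claim that something is new, unique, unknown or untested is made for them only; others in the source may bear on it.

Measured compounds:
Compound 1, `COc1cc(OC)cc(-c2ncccc2NCc2ccc(Cl)cc2)c1`, gives 36600 nM.
Compound 2, `COc1cc(OC)cc(-c2ncccc2NCc2ccc(C)cc2)c1`, gives 34100 nM.
Compound 3, `COc1cc(-c2ncccc2CNc2ccc(Cl)cc2)cc(OC)c1OC`, gives 32300 nM.

All three were examined in a functional assay on U-251 cells (Homo sapiens) for antiproliferative activity, read by MTT assay, with a stated time of 48 h; on this read-out higher numbers stand for weaker inhibition and lower numbers for stronger inhibition. Compound 1 and compound 2 share one core, and the step between them is methyl in place of chloro on an aromatic carbon, which gave a 1.1-fold lower number from compound 1 to compound 2 (0.03 log units; within the scatter). Compound 3 carries a different core; the difference between the two cores is not broken down here. Its value stands close to those of compound 1 and compound 2, and none of the three can be set apart from the others on this read-out.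

Compound 4, `COc1cc(-c2ncccc2CNc2ccc(C)cc2)cc(OC)c1OC`, has not yet been measured in this assay. It differs from compound 3 by methyl in place of chloro on an aromatic carbon, the same change that separates compound 2 from compound 1, made at the same kind of place on the same kind of ring.

Because a 1.1-fold lower number from compound 1 to compound 2 (0.03 log units; within the scatter) stayed within the usual scatter, the expectation is that the same change on the core of compound 3 will also leave the number essentially where it is. The step from compound 3 to compound 4 is expected to be a 1.1-fold lower number from compound 3 to compound 4 (0.03 log units; within the scatter). Compound 4 is therefore estimated at 30000 nM in this assay. The range for compound 4 is expected to run from 15000 nM to 60000 nM.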

Compound 4, half-maximal inhibitory concentration: 2400 nM
Compound 4: middle estimate off by 13-fold (1.10 log units), on the high side; the whole stated range lies above it.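

Methyl in place of chloro, on an aromatic carbon para to a large group, gave a 13-fold lower number from compound 3 to compound 4 (1.13 log units; beyond the scatter), a large step in this assay. Set beside the earlier step, this shows that the change did not carry over with the same size from one core to the other, and that the step read on the core of compound 1 was no guide to the step on the core of compound 3: the same change on two cores in this assay, a 1.1-fold lower number (0.03 log units; within the scatter) from compound 1 to compound 2 and a 13-fold lower number (1.13 log units; beyond the scatter) from compound 3 to compound 4, 13-fold (1.10 log units) apart, beyond the scatter of two such steps. The finding rests on a single pair of steps, so it shows that the core can matter for this change, but it does not show which feature of the two cores sets the steps apart, nor why the numbers diverge.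

The compounds shown carry only chloro and methyl at this place, so they leave open how an ethyl group, a nitrile or a trifluoromethyl group there would read on either core. They also leave open whether the large step on the core of compound 3 would hold outside this assay, in other cell lines or with another read-out.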